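This account rests on a few compounds, and the source may have more. Where it says the series, first, only, none or still open, it means among the compounds named here.

In a functional assay on the whole organism (strain Kunming) with Mus musculus as the target, with a stated time of 0.5 h (on this read-out higher numbers stand for an effect only at larger amounts of compound and lower numbers for an effect already at smaller amounts), compound 1 `COc1cc(OC)c(OC)cc1/C=C/COC(=O)/C=C/c1ccccc1C(F)(F)F` gives 85.7 mg/kg and compound 2 `COc1cccc(/C=C/C(=O)OC/C=C/c2cc(OC)c(OC)cc2OC)c1` gives 72.9 mg/kg. With only these two numbers available, compound 2 stands within the scatter of compound 1, and neither can be ranked above the other. The next structure, compound 3 `COc1cc(OC)c(OC)cc1/C=C/COC(=O)/C=C/c1ccc(Cl)cc1`, keeps the shared core of compound 2 and differs in one group: 4-chlorophenyl in place of 3-methoxyphenyl on a double-bonded chain carbon bound to a double-bonded chain carbon. In words, 4-chlorophenyl stands in place of 3-methoxyphenyl. Among the compounds with values here, one measured step bears on this place, a 1.2-fold lower number from compound 1 to compound 2 (0.07 log units; within the scatter). That exchange of one aromatic group for another is small, but neither compound carries 4-chlorophenyl, so the evidence is only indirect. No step beyond the scatter is therefore expected in this assay. The estimate amounts to a 1.0-fold higher number from compound 2 to compound 3 (0.01 log units; within the scatter). For compound 3 the expected value is 75 mg/kg, with an estimated range of 38 mg/kg to 150 mg/kg.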

Compound 3, dose for half-maximal effect: 53.4 mg/kg
Estimate against measurement, compound 3: 1.4-fold (0.15 log units) above; low and high end bracket the measured number.
By their numbers in this assay, from the lowest: compounds 3, 2 and 1 (each within the scatter of the next).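

Placing 4-chlorophenyl on a double-bonded chain carbon bound to a double-bonded chain carbon in this assay gives a 1.4-fold lower number from compound 2 to compound 3 (0.14 log units; within the scatter), and the exchange for 2-(trifluoromethyl)phenyl gives a 1.6-fold lower number from compound 1 to compound 3 (0.21 log units; within the scatter). Three differently substituted phenyl groups have now been compared at this place, including one that carries chlorine, and all three stand within the scatter of one another, so this series shows no separable effect of the exchange. No measurement is available that would account for how close these numbers lie.

Going by these compounds, what remains open is whether a non-aromatic group at this place, such as an amine, a carboxylic acid or a longer chain, would move the number beyond the scatter. Equally open, on these data alone, is what a change elsewhere in the shared core would do.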